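Notes on the methoxy-to-hydroxy step from compound 3 to compound 4

A few compounds are considered here, and "the series" means these few. Any claim that something is new, unique, unknown or untested is made for them only; others in the source may bear on it.

Measured compounds:
compound 1 `O=C(Nc1cccc(-n2cc(-c3ccncc3)c(-c3ccc(Cl)c(O)c3)n2)c1)Nc1cccc(C(F)(F)F)c1` — > 32500 nM
compound 2 `O=C(Nc1cccc(-n2cc(-c3ccncc3)c(-c3ccc(Cl)c(O)c3)n2)c1)Nc1ccc(Cl)c(Cl)c1` — > 32500 nM
compound 3 `COc1cc(-c2nn(-c3cccc(NC(=O)Nc4ccc(Cl)c(C(F)(F)F)c4)c3)cc2-c2ccncc2)ccc1Cl` — 5870 nM

Among the compounds with values here, in a functional assay on OVCAR-8 cells (Homo sapiens) for inhibition, read by sulforhodamine B assay, with a stated time of 48 h (on this read-out higher numbers stand for weaker inhibition of growth and lower numbers for stronger inhibition of growth), compound 3 gives 5870 nM, the only number in the set. The other two values are limits of the assay. Compound 1 stops at the limit > 32500 nM. Compound 2 likewise stops at the limit > 32500 nM. Within the data shown here, the single step between measured compounds, a step that the two limits leave unreadable from compound 1 to compound 2, changes the aryl group on the amide-type nitrogen and leaves the oxygen untouched, so it does not bear on the step in hand, and its size is not readable in any case.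

Compound 4 `O=C(Nc1cccc(-n2cc(-c3ccncc3)c(-c3ccc(Cl)c(O)c3)n2)c1)Nc1ccc(Cl)c(C(F)(F)F)c1` differs from compound 3 by hydrogen in place of methyl on an oxygen on an aromatic ring. Among the measured compounds shown here, no measured pair isolates this change. What the set does show is the limit of > 32500 nM in this assay, at which 2 of the 3 values shown sit, and both compounds at that limit carry 4-chloro-3-hydroxyphenyl, as compound 4 does. The step of a 4.3-fold higher number from compound 3 to compound 4 (0.63 log units; beyond the scatter) is therefore expected to run toward weaker inhibition of growth, with a fair chance that only a limit is reported. Compound 4 is estimated at 25000 nM, within 7000 nM to 70000 nM.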

Compound 4, concentration for total growth inhibition: 2280 nM
Compound 4: middle estimate off by 11-fold (1.04 log units), on the high side, and the stated range ends above it.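

In this assay, the 4-chloro-3-hydroxyphenyl group does not by itself bring a compound to the limit: compound 4 carries it and still gives a number, and hydrogen in place of methyl on the oxygen brings stronger inhibition of growth (a 2.6-fold lower number from compound 3 to compound 4 (0.41 log units; beyond the scatter)). With the hydroxy group held constant, the substituents on the other aryl group carry the larger differences, seen for trifluoromethyl in place of chloro (an at least 14-fold lower number from compound 2 to compound 4 (1.15 log units; beyond the scatter)) and for chloro in place of hydrogen (an at least 14-fold lower number from compound 1 to compound 4 (1.15 log units; beyond the scatter)). From the compounds shown here alone, both of these steps start from a limit and not from a number, so their full size stays unknown: the limit of > 32500 nM in this assay, at which 2 of the 4 values shown sit.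

Going by these compounds, the methoxy-to-hydroxy step is read in one pair only, so its course with the 3-(trifluoromethyl)phenyl and 3,4-dichlorophenyl groups stays open. Also open, on these data alone, is how an ethoxy group or an amine at this place would compare with methoxy and hydroxy.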